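Trading (Oxolan-2-yl)carbonyl for 2-Hydroxyethyl on One Oxygen

The source may report more compounds than this note shows. Statements on the series, on what has been measured and on what is new or still open speak of the compounds shown alone.

Of the compounds shown here, two built on the shared core have been measured so far. In a functional assay on HeLa cells (Homo sapiens) for cytotoxicity, read by MTT assay (a higher number here means a weaker inhibitor, a lower number a stronger inhibitor), compound 1 `COC(C)CO[C@H](CC=C(C)C)C1=CC(=O)c2c(O)ccc(O)c2C1=O` gives 53400 nM and compound 2 `CC(C)=CC[C@@H](OC(=O)C1CCCO1)C1=CC(=O)c2c(O)ccc(O)c2C1=O` gives 17000 nM, the lower of the two numbers and so the stronger inhibitor of this pair. The unmeasured compound 3 `CC(C)=CC[C@@H](OCCO)C1=CC(=O)c2c(O)ccc(O)c2C1=O` differs from compound 2 at one place: 2-hydroxyethyl in place of (oxolan-2-yl)carbonyl on an oxygen on a saturated carbon. Here 2-hydroxyethyl stands in place of (oxolan-2-yl)carbonyl on an oxygen on a saturated carbon. Within the data shown here, only one measured step bears on this change: a 3.1-fold lower number from compound 1 to compound 2 (0.50 log units; beyond the scatter), a modest step beyond the scatter, with (oxolan-2-yl)carbonyl in place of 2-methoxypropyl on that same oxygen. Compound 3 loses that (oxolan-2-yl)carbonyl again and, like compound 1, carries a group without a carbonyl there. However, 2-hydroxyethyl is not 2-methoxypropyl, so this single step is only a rough guide. A modest move to a higher number in this assay is therefore expected, of about the same size or smaller. The estimated step is a 2.2-fold higher number from compound 2 to compound 3 (0.35 log units; beyond the scatter). For compound 3 the expected value is 38000 nM, with an estimated range of 13000 nM to 90000 nM.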

Compound 3, half-maximal inhibitory concentration: 18600 nM
For compound 3 the middle estimate is 2.0-fold (0.31 log units) above the measured one; measured number inside the range.
By their numbers in this assay, from the lowest: compounds 2 and 3 (each within the scatter of the next); then compound 1.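

In this assay, putting 2-hydroxyethyl in place of (oxolan-2-yl)carbonyl on this oxygen gives a 1.1-fold higher number from compound 2 to compound 3 (0.04 log units; within the scatter), so a group of 7 heavy atoms with a five-membered ring and a group of 3 heavy atoms with no ring cannot be told apart here. The carbonyl therefore does not appear to be required for a number in this range, and the step from compound 1 shows that the rest of the group on this oxygen can matter: hydroxymethyl in place of 1-methoxyethyl, on a saturated chain carbon bound to that oxygen, gives a 2.9-fold lower number from compound 1 to compound 3 (0.46 log units; beyond the scatter), a modest step. Nothing available explains why these numbers fall as they do.

Only three groups on this oxygen are shown, so it remains open whether 2-methoxyethyl, which differs from 2-hydroxyethyl only by a methyl on its end oxygen, would stay with compound 3 or move towards compound 1. From the compounds shown here alone, the effect of an amine, a carboxylic acid or a longer chain ending in a hydroxyl at this place also remains unknown.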